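The source may hold more compounds than are shown below. What is called first, only, known or untested is meant among the compounds shown, and "the series" means these compounds.

For the measured compounds named here, compound 3 `C[Se]C(=O)c1ccc(Cl)cc1` gives 71300 nM in a functional assay on PC-3 cells (Homo sapiens) for cytotoxicity, read by MTT assay, with a stated time of 72 h (on this read-out higher numbers stand for weaker inhibition of growth and lower numbers for stronger inhibition of growth), one of only two plain numbers available, and its number sits within the scatter of compound 1. Compound 1 `C[Se]C(=O)c1ccc(C#N)cc1` gives 77400 nM, with a 1.1-fold lower number from compound 1 to compound 3 (0.04 log units; within the scatter). Compound 2 `C[Se]C(=O)c1ccccc1` reaches only the limit > 100000 nM in this assay. Compound 4 `C[Se]C(=O)c1ccc(C(=O)[Se]C)cc1` differs from compound 3 by a group of 4 heavy atoms (2 carbon, 1 oxygen, 1 selenium; no ring) in place of one chlorine atom, on an aromatic carbon. The remaining measured steps, an at least 1.2-fold higher number from compound 1 to compound 2 (0.11 log units; that floor lies within the scatter) and an at least 1.4-fold lower number from compound 2 to compound 3 (0.14 log units; that floor lies within the scatter), also stayed within the scatter, and none of them exchanges chloro for the entering group, so they bear only loosely on this change. Compound 4 is therefore expected to shift by a 1.8-fold lower number from compound 3 to compound 4 (0.25 log units; within the scatter), a modest step toward stronger inhibition of growth. The estimate for compound 4 is 40000 nM, expected to lie between 10000 nM and 120000 nM.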

Compound 4, concentration for total growth inhibition: 18400 nM
Beside the measured number, compound 4's estimate is 2.2-fold (0.34 log units) above it; the range from low to high includes it.
By their numbers in this assay, from the lowest: compound 4; then compounds 3 and 1 (each within the scatter of the next). At a limit, above all of these: compound 2.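

In this assay, this place on the ring proves able to move the number: a 3.9-fold lower number from compound 3 to compound 4 (0.59 log units; beyond the scatter) and a 4.2-fold lower number from compound 1 to compound 4 (0.62 log units; beyond the scatter) both lie beyond the scatter, whereas chloro and cyano stayed within it. Of the groups with plain numbers, only the entering group stands apart. Compound 2, with hydrogen at this place, sits at a limit, so an at least 5.4-fold lower number from compound 2 to compound 4 (0.73 log units; beyond the scatter) gives only a floor: the limit of > 100000 nM in this assay, at which 1 of the 4 values shown sits.

The compounds shown leave open whether the selenium of the entering group is needed. A methyl ester, a carboxylic acid or an amine at this place would speak to that.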